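Swapping an Aromatic Ring for Cyclohexyl: Permeability Outlook

The source may hold more compounds than are shown below. What is called first, only, known or untested is meant among the compounds shown, and "the series" means these compounds.

Compound 1, `Fc1ccc(-c2ccc3c(NCCCNCc4ccco4)ccnc3c2)cc1`: 237 10^-6 cm/s
Compound 2, `COc1ccc(-c2ccc3c(NCCCNCc4ccco4)ccnc3c2)cc1`: 237 10^-6 cm/s
Compound 3, `COc1ccc(-c2ccc3c(NCCCNCc4cc(F)ccc4OC)ccnc3c2)cc1`: 237 10^-6 cm/s

Of the compounds shown here, three sharing one core have been measured in an ADME assay for permeability, using PAMPA, with a stated time of 30 min, at pH 7.4; on this read-out lower numbers stand for lower permeability and higher numbers for higher permeability. In this assay compound 2 stands level with compounds 1 and 3 at the digits shown: the step of no change at the digits printed from compound 1 to compound 2 (within the scatter) and the step of no change at the digits printed from compound 2 to compound 3 (within the scatter) both stay within the scatter, so the three values cannot be told apart.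

Compound 4, `c1coc(CNCCCNc2ccnc3cc(C4CCCCC4)ccc23)c1`, has not yet been measured. It differs from compound 2 in one place: cyclohexyl in place of 4-methoxyphenyl on an aromatic carbon. The step from compound 1 to compound 2 is the one that bears on it most closely, since it alters the same place on the core, and it showed no movement; the step from compound 2 to compound 3, at a different place, showed none either. Neither step exchanges an aromatic ring for a non-aromatic one, so the match is loose. On this evidence, a step of no change at the digits printed from compound 2 to compound 4 (within the scatter) from compound 2 to compound 4 is expected, no larger than the scatter. For compound 4 the estimate in this assay is 237 10^-6 cm/s, with a range from 120 10^-6 cm/s to 400 10^-6 cm/s.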

Compound 4, apparent permeability: 23 10^-6 cm/s
For compound 4 the middle estimate is 10-fold (1.01 log units) above the measured one; measured number outside the range, below it.
By their numbers in this assay, from the lowest: compound 4; then compounds 1, 2 and 3 (each within the scatter of the next).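

In this assay, the place on the shared core that carries these rings proves able to shift the read-out: cyclohexyl in place of 4-methoxyphenyl gives a 10-fold lower number from compound 2 to compound 4 (1.01 log units; beyond the scatter), and cyclohexyl in place of 4-fluorophenyl gives a 10-fold lower number from compound 1 to compound 4 (1.01 log units; beyond the scatter). The exchange of fluoro for methoxy on the aromatic ring at this place had stayed within the scatter, so these compounds show a large step only where the aromatic ring itself gives way to a non-aromatic one. No measurement shown accounts for this drop.

Still open, going by these compounds, is whether another non-aromatic ring at this place, such as piperidine or morpholine, would give a number near that of compound 4. Also open, on these data alone, is how a plain phenyl or a pyridine ring would compare with compound 2.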